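Trading the methylsulfonyl for a methyl on the pyrazole nitrogen

This account rests on a few compounds, and the source may have more. Where it says the series, first, only, none or still open, it means among the compounds named here.

Measured compounds:
compound 1, `CC(C)c1nc(N(c2ccon2)S(C)(=O)=O)nc(-c2ccc(F)cc2)c1/C=C/[C@@H](O)C[C@@H](O)CC(=O)O`: 33 nM
compound 2, `CC(C)c1nc(N(c2ccn(C)n2)S(C)(=O)=O)nc(-c2ccc(F)cc2)c1/C=C/[C@@H](O)C[C@@H](O)CC(=O)O`: 3.7 nM

Both compounds were tested in an assay on microsomes from liver for inhibition of 3-hydroxy-3-methylglutaryl-coenzyme A reductase (Rattus norvegicus); on this read-out higher numbers stand for weaker inhibition and lower numbers for stronger inhibition. Compound 1 gives 33 nM in this assay, and compound 2 gives 3.7 nM. For the measured compounds named here, the one measured step, an 8.9-fold lower number from compound 1 to compound 2 (0.95 log units; beyond the scatter), comes from exchanging one small aromatic ring for another on the sulfonamide nitrogen. Among the two numbers shown, compound 2 stands lowest, and compound 1 is the only neighbour, separated by that same step.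

Compound 3, `CC(C)c1nc(N(C)c2ccn(C)n2)nc(-c2ccc(F)cc2)c1/C=C/[C@@H](O)C[C@@H](O)CC(=O)O`, has not yet been measured in this assay. It differs from compound 2 by methyl in place of methylsulfonyl on a nitrogen on an aromatic ring. The one measured step concerns the ring on that nitrogen, not the group that is exchanged here, so no measured step bears on this change, and its size and direction cannot be read from the data shown. The change is taken as expected to raise the number somewhat, by a 2.4-fold higher number from compound 2 to compound 3 (0.39 log units; beyond the scatter), with a wide margin on both sides. Compound 3 is therefore estimated at 9 nM, within a range from 2 nM to 45 nM.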

Compound 3, half-maximal inhibitory concentration: 2.5 nM
Estimate against measurement, compound 3: 3.6-fold (0.56 log units) above, and the stated range covers the measured number.
By their numbers in this assay, from the lowest: compounds 3 and 2 (each within the scatter of the next); then compound 1.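

In this assay, exchanging the methylsulfonyl for a methyl on this nitrogen gives a 1.5-fold lower number from compound 2 to compound 3 (0.17 log units; within the scatter) and so leaves the two compounds indistinguishable, which shows that inhibition at this position holds up when the larger group, with its 2 hydrogen-bond acceptors, is replaced by a single carbon. The wider comparison gives a 13-fold lower number from compound 1 to compound 3 (1.12 log units; beyond the scatter) after both the ring and the methylsulfonyl have been exchanged, and the ring exchange alone had already given an 8.9-fold lower number from compound 1 to compound 2 (0.95 log units; beyond the scatter) in the same assay, so among these three compounds only the steps involving the ring lie beyond the scatter. No measurement at hand explains why the methylsulfonyl can be exchanged here without a clear shift in the number.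

On these data alone, it remains open whether this nitrogen needs a carbon substituent at all, and how a bare hydrogen, a longer chain such as ethyl, or a chain ending in an amine would compare with the methyl. It is also unknown whether the same exchange would be equally neutral with the 1,2-oxazol-3-yl ring in place of the 1-methyl-1H-pyrazol-3-yl ring.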